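The source may report more compounds than this note shows. Statements on the series, on what has been measured and on what is new or still open speak of the compounds shown alone.

Measured so far in a physicochemical assay for solubility; on this read-out lower numbers stand for lower solubility and higher numbers for higher solubility:

- Compound 1 `CNC(=O)c1cc(C(=O)NC2CCC2)cn(Cc2ccccn2)c1=O`: >= 103 ug/mL (a limit)
- Compound 2 `CNC(=O)c1cc(C(=O)NC2CCC2)cn(Cc2cccnc2)c1=O`: >= 99 ug/mL (a limit)

Compound 2 has no exact number on this read-out. Its value of >= 99 ug/mL is a limit of the assay. Compound 1 is likewise known only as a limit.

The next structure is compound 3 `CNC(=O)c1cc(C(=O)NC2CCC2)cn(Cc2ccncc2)c1=O`, which has the same atoms as compound 2, joined differently: pyridin-4-yl in place of pyridin-3-yl on a saturated chain carbon bound to an aromatic nitrogen. In short, pyridin-4-yl stands in place of pyridin-3-yl on a saturated chain carbon bound to an aromatic nitrogen.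

For the measured compounds named here, one measured step bears on this change, a similar move of the ring nitrogen: a step that the two limits leave unreadable from compound 1 to compound 2. It offers no size to carry over, so no step beyond the usual scatter is expected in this assay.

The expected step is a step that the limit leaves unreadable from compound 2 to compound 3.

For compound 3 the estimate is 105 ug/mL, with an expected range of 60 ug/mL to 170 ug/mL.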

Compound 3, solubility: >= 118 ug/mL
Compound 3: only a limit was reported (the forecaster's own chance of this, stated with the estimate: 80%); at least 1.1-fold (0.05 log units) between middle value and limit.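

In this assay, for the compounds shown here, compound 1, compound 2 and compound 3 are each known only as a limit, so no step among them can be read. On these data alone, whether pyridin-2-yl, pyridin-3-yl and pyridin-4-yl give different values in this assay stays open.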